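Methyl for Chloro, Repeated on a Second Core

The compounds below may be only part of what the source reports. "The series", "measured", "known", "first", "only" and "open" are said of these compounds alone.

Compound 1 `Cc1ccc(Nc2nc(N)nc(COc3ccc4c(C)cc(=O)oc4c3)n2)cc1C` and compound 2 `Cc1cc(Nc2nc(N)nc(COc3ccc4c(C)cc(=O)oc4c3)n2)ccc1Cl` differ at one place: methyl in place of chloro on an aromatic carbon. In an assay on COS-7 cells for agonist activity at Free fatty acid receptor 1 (Homo sapiens), read by scintillation counting and inositol phosphate accumulation, with a stated time of 90 min (a higher number here means that more compound is needed for the effect, a lower number that less compound is needed), compound 2 gives 240 nM and compound 1 gives 210 nM, a step of a 1.1-fold lower number from compound 2 to compound 1 (0.06 log units; within the scatter). Compound 3 `Cc1ccc(Nc2nc(N)nc(COc3cc(Cl)cc(N4CCCC4=O)c3)n2)cc1Cl` carries a different core; the difference between the two cores is not broken down here. In this assay compound 3 gives 160 nM, a value within the scatter of both others. Compound 4 `Cc1cc(OCc2nc(N)nc(Nc3ccc(C)c(Cl)c3)n2)cc(N2CCCC2=O)c1` is made from compound 3 by the same kind of change, (methyl in place of chloro on an aromatic carbon); the surroundings differ, since in compound 2 the carbon sits ortho to a methyl group and para to a large group, while in compound 3 it sits meta to a 2-oxopyrrolidin-1-yl group and meta to a large group. Because the earlier step of a 1.1-fold lower number from compound 2 to compound 1 (0.06 log units; within the scatter) stayed within the scatter, a similarly small step is expected here: a 1.1-fold lower number from compound 3 to compound 4 (0.03 log units; within the scatter). Compound 4 is therefore estimated at 150 nM, between 80 nM and 300 nM.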

Compound 4, half-maximal effective concentration: 20 nM
Compound 4: the middle estimate sits 7.5-fold (0.88 log units) above what was measured; the measured number lies below the stated range.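

On the second core, methyl in place of chloro brings an 8.0-fold lower number from compound 3 to compound 4 (0.90 log units; beyond the scatter) in this assay. The same change therefore did not carry over at the same size from one core to the other: the same change on two cores in this assay, a 1.1-fold lower number (0.06 log units; within the scatter) from compound 2 to compound 1 and an 8.0-fold lower number (0.90 log units; beyond the scatter) from compound 3 to compound 4, 7.0-fold (0.85 log units) apart, beyond the scatter of two such steps

This shows that a step read on one core cannot simply be assumed on another in this series, but two pairs cannot show why the steps differ or predict the step on a third core. On these data alone, whether the larger step depends on the 2-oxopyrrolidin-1-yl group remains open. So does whether an ethyl group, a methoxy group or an amine at the same place would give a step like that of methyl.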